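Swapping the sulfonyl for a chloropyrimidinyl on the amine

This account rests on a few compounds, and the source may have more. Where it says the series, first, only, none or still open, it means among the compounds named here.

Compound 1 `COc1ccc(C(=O)N[C@@H](C)Cn2ccc(-c3ccc(C#N)c(Cl)c3)n2)cc1`: 1540 nM
Compound 2 `CC(Cn1ccc(-c2ccc(C#N)c(Cl)c2)n1)C(=O)Nc1cccc(C(C)O)c1`: > 30000 nM
Compound 3 `C[C@@H](Cn1ccc(-c2ccc(C#N)c(Cl)c2)n1)NS(=O)(=O)c1cccnc1`: 2450 nM

All three were tested in a functional assay on VCaP cells (Homo sapiens) for antiproliferative activity, read by CCK-8 assay, with a stated time of 6 days; a higher number here means a weaker inhibitor, a lower number a stronger inhibitor. Compound 2 returned only a limit of the assay, namely (the limit of > 30000 nM in this assay, at which 1 of the 3 values shown sits). Among the two numbers, compound 3 stands highest, with compound 1 nearest; that gap lies within the scatter, so no order between them is claimed.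

Compound 4 `C[C@@H](Cn1ccc(-c2ccc(C#N)c(Cl)c2)n1)Nc1nccc(Cl)n1` has not yet been measured. It differs from compound 3 by 4-chloropyrimidin-2-yl in place of (pyridin-3-yl)sulfonyl on an amine nitrogen. Going by the values given here, no measured pair shows this change, so the expectation rests on compound 3 alone. A modest step toward a stronger inhibitor is expected, though one hardly beyond the scatter: the estimated step is a 1.6-fold lower number from compound 3 to compound 4 (0.21 log units; within the scatter). Compound 4 is estimated at 1500 nM, with a range from 400 nM to 6000 nM.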

Compound 4, half-maximal inhibitory concentration: > 30000 nM
Compound 4: a limit, no number; the forecaster's own chance of this, stated with the estimate: 15%; at least 20-fold (1.30 log units) between middle value and limit.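

On this amine nitrogen the substituent is not freely exchangeable in this assay: 4-chloropyrimidin-2-yl in place of (pyridin-3-yl)sulfonyl gives an at least 12-fold higher number from compound 3 to compound 4 (1.08 log units; beyond the scatter). Compound 4 returns only a limit of the assay: the limit of > 30000 nM in this assay, at which 2 of the 4 values shown sit. Going by these compounds alone, this single step is the first reading of any change at this place, and it shows that this exchange alone, on an otherwise unchanged structure, is enough for a large loss.

Which part of the exchange matters stays open: the chlorine, the pyrimidine ring or the departure of the sulfonyl. A plain pyrimidin-2-yl or a methylsulfonyl on the same nitrogen would separate these.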